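This account rests on a few compounds, and the source may have more. Where it says the series, first, only, none or still open, it means among the compounds named here.

In an in vitro ADME assay on microsomes from liver (Homo sapiens) for metabolic stability, tested at 1 uM (on this read-out lower numbers stand for a shorter-lived compound and higher numbers for a longer-lived compound), compound 3 (`CO[C@@H]1COCC[C@@H]1N[C@@H]1CC[C@@](C(=O)N2C[C@@H]3C[C@H]2CN3C(=O)CC(C)(C)C)(C(C)C)C1`) gives > 2 h, which is a limit of the assay and not a number. Compound 1 (`CC(C)[C@]1(C(=O)N2C[C@@H]3C[C@H]2CN3C(=O)CC(C)(C)C)CC[C@@H](NC2CCOCC2)C1`) gives > 2 h, also a limit. Compound 2 (`CC(C)[C@]1(C(=O)N2C[C@@H]3C[C@H]2CN3C(=O)C(C)(C)C)CC[C@@H](NC2CCOCC2)C1`) gives > 2 h, again a limit. The whole set therefore reads (the limit of > 2 h in this assay, at which 3 of the 3 values shown sit). Compound 4 (`CO[C@@H]1COCC[C@@H]1N[C@@H]1CC[C@@](C(=O)N2C[C@@H]3C[C@H]2CN3C(=O)C(C)(C)C)(C(C)C)C1`) differs from compound 3 by tert-butyl in place of neopentyl on a carbonyl carbon. Among the compounds with values here, the same exchange appears in a step that the two limits leave unreadable from compound 1 to compound 2, the closest precedent, while the methoxy change appears in a step that the two limits leave unreadable from compound 1 to compound 3. Neither size can be read, so no shift beyond the scatter is expected in this assay. The expected change is a step that the limit leaves unreadable from compound 3 to compound 4. For compound 4 the estimated half-life is 2.5 h, with an expected range of 1.5 h to 5 h.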

Compound 4, half-life: > 2 h
Compound 4: only a limit was reported (the forecaster's own chance of this, stated with the estimate: 85%); the middle value does not contradict the limit.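

Neither the step from compound 3 to compound 4 nor the step from compound 2 to compound 4 can be read, because all four compounds sit at the same limit: the limit of > 2 h in this assay, at which 4 of the 4 values shown sit. The compounds shown leave open the actual half-life of each compound in this assay, and so whether either exchange alters it.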